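A few compounds are considered here, and "the series" means these few. Any claim that something is new, unique, unknown or untested is made for them only; others in the source may bear on it.

Working notes on the series.

Compound 1 `CCC1=C(O)c2c(oc(-c3ccc(C(F)(F)F)cc3)cc2=O)C(CC)(CC)C1=O` is the reference point. In a functional assay on KBVIN cells (Homo sapiens) for antiproliferative activity, read by sulforhodamine B assay, with a stated time of 3 days (a lower number here means that less compound is needed, a higher number that more compound is needed for the effect), compound 1 gives 10.4 uM, the highest of the three numbers recorded so far. Compound 2 `CCC1=C(O)c2c(oc(-c3ccc(OC)cc3)cc2=O)C(CC)(CC)C1=O` gives 0.68 uM in this assay, and compound 3 `CCC1=C(O)c2c(oc(-c3ccc(F)cc3)cc2=O)C(CC)(CC)C1=O` gives 1.85 uM. Both replacements of the trifluoromethyl group moved the number down: a 15-fold lower number from compound 1 to compound 2 (1.18 log units; beyond the scatter) and a 5.6-fold lower number from compound 1 to compound 3 (0.75 log units; beyond the scatter). Between the two replacements, a 2.7-fold higher number from compound 2 to compound 3 (0.43 log units; beyond the scatter).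

Compound 4 `CCC1=C(O)c2c(oc(-c3ccc(CBr)cc3)cc2=O)C(CC)(CC)C1=O` is not yet measured. Its change from compound 1 is bromomethyl in place of trifluoromethyl on an aromatic carbon. The two measured steps leaving compound 1 both bear on this change, since each also removes the trifluoromethyl group from the same aromatic carbon, and both gave lower numbers, one large and one modest. Within the data shown here, no measured step introduces a bromomethyl group, so the size for compound 4 is uncertain; a modest lowering, closer to the fluoro case than to the methoxy case, is expected, i.e. a 3.5-fold lower number from compound 1 to compound 4 (0.54 log units; beyond the scatter). The estimate for compound 4 in this assay is 3 uM, with a range of 1 uM to 9 uM.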

Compound 4, concentration for half-maximal effect: 27.9 uM
Beside the measured number, compound 4's estimate is 9.3-fold (0.97 log units) below it; the measured number lies above the stated range.
By their numbers in this assay, from the lowest: compound 2; then compound 3; then compound 1; then compound 4.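

Bromomethyl is the first replacement of trifluoromethyl, on this aromatic carbon para to a large group, that raises the number in this assay (a 2.7-fold higher number from compound 1 to compound 4 (0.43 log units; beyond the scatter)). Removing trifluoromethyl therefore does not by itself lower the number: the result depends on the group that enters, and bromomethyl stands well apart from the other two replacements (a 15-fold higher number from compound 3 to compound 4 (1.18 log units; beyond the scatter); a 41-fold higher number from compound 2 to compound 4 (1.61 log units; beyond the scatter)). Nothing available here accounts for this reversal.

The compounds shown leave open whether the higher number goes with the bromine or with the carbon that carries it, which a plain methyl, chloromethyl or hydroxymethyl group on the same aromatic carbon would help to separate. Also open, on these data alone, is whether an amine or a carboxylic acid there would fall with methoxy and fluoro or with bromomethyl.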